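Cyclopentenyl for Oxazolyl on a Ubiquitin Hydrolase Inhibitor

A few compounds are considered here, and "the series" means these few. Any claim that something is new, unique, unknown or untested is made for them only; others in the source may bear on it.

In an assay on isolated protein for inhibition of ubiquitin carboxyl-terminal hydrolase 7 (Homo sapiens), with stated times of 30 min and 2 h (a lower number here means a stronger inhibitor, a higher number a weaker inhibitor), compound 1 `Cn1nc2c(=O)n(CC3(O)CCN(Cc4ccc(-c5cnco5)cc4Cl)CC3)cnc2c1-c1ccc(CN)cc1` gives 71.6 nM, the second highest of three numbers. Compound 3 `CCCNCc1ccc(-c2c3ncn(CC4(O)CCN(Cc5ccc(-c6ccco6)cc5Cl)CC4)c(=O)c3nn2C)cc1` gives 43.9 nM, within the scatter of compound 1. Compound 2 `Cn1nc2c(=O)n(CC3(O)CCN(Cc4ccc(-c5ccco5)cc4Cl)CC3)cnc2c1-c1ccc(OC(F)F)cc1` gives 179 nM, a higher number that lies beyond the scatter of compound 1. Within the data shown here, the only step with a single change, a 4.1-fold lower number from compound 2 to compound 3 (0.61 log units; beyond the scatter), alters a group on the other aryl ring and not the position now in question. Compound 4 `Cn1nc2c(=O)n(CC3(O)CCN(Cc4ccc(C5=CCCC5)cc4Cl)CC3)cnc2c1-c1ccc(CN)cc1` differs from compound 1 by cyclopent-1-en-1-yl in place of 1,3-oxazol-5-yl on an aromatic carbon. Among the measured compounds shown here, no measured step touches that group, so the step in this assay from compound 1 is expected to stay small, with its direction uncertain. Compound 4 is therefore estimated at 110 nM, with a range from 40 nM to 300 nM. That expectation corresponds to a 1.5-fold higher number from compound 1 to compound 4 (0.19 log units; within the scatter).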

Compound 4, half-maximal inhibitory concentration: 76.9 nM
Beside the measured number, compound 4's estimate is 1.4-fold (0.16 log units) above it, within the range that was stated.
By their numbers in this assay, from the lowest: compounds 3, 1 and 4 (each within the scatter of the next); then compound 2.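

In this assay, among these compounds, putting cyclopent-1-en-1-yl in place of 1,3-oxazol-5-yl gives a 1.1-fold higher number from compound 1 to compound 4 (0.03 log units; within the scatter), the first reading at this position. The hydrogen-bond acceptors and hetero atoms of 1,3-oxazol-5-yl are absent from the entering ring of carbon only, yet the two numbers stay within the scatter, so in this pair those atoms are not required to hold the number. No supporting data explain this result. On these data alone, whether a carboxylic acid, an amine or a saturated cyclopentyl ring on this aromatic carbon would hold the number stays open.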